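The source may hold more compounds than are shown below. What is called first, only, known or untested is meant among the compounds shown, and "the series" means these compounds.

Compound 1, `Cn1nc(-c2ccnc(Nc3ccc(O)cc3)n2)c2ccccc21`: in a functional assay on HCT-116 cells (Homo sapiens) for antiproliferative activity, read by MTT assay, with a stated time of 72 h (on this read-out higher numbers stand for weaker inhibition of growth and lower numbers for stronger inhibition of growth), compound 1 gives 8430 nM.
Compound 2, `Cn1nc(-c2ccnc(Nc3cccc(O)c3)n2)c2ccccc21`: in this assay compound 2 gives 17200 nM.
Compound 3, `Cc1cccc(Nc2nccc(-c3nn(C)c4ccccc34)n2)c1`: in this assay compound 3 gives 9420 nM.

Among these three, only compound 1 and compound 2 are separated beyond the scatter, with a 2.0-fold higher number from compound 1 to compound 2 (0.31 log units; beyond the scatter). The number for compound 3 is not separable from either of the others: a 1.1-fold higher number from compound 1 to compound 3 (0.05 log units; within the scatter), and a 1.8-fold lower number from compound 2 to compound 3 (0.26 log units; within the scatter). Compound 3 therefore stands with the others, neither the strongest nor the weakest of the set on the evidence shown.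

Compound 4, `Cn1nc(-c2ccnc(Nc3cccc([N+](=O)[O-])c3)n2)c2ccccc21`, keeps the shared core and the same substituted phenyl ring, and differs from compound 3 in one place: nitro in place of methyl on an aromatic carbon. For the measured compounds named here, the only measured step that touches the same position is the one from compound 2 to compound 3, where one group was swapped for another on that aromatic carbon and the number moved within the scatter. The other two steps change the position of a group rather than its identity, so they bear only indirectly. No swap at this position has yet moved the number beyond the scatter, so for compound 4 the expected step is a 1.1-fold higher number from compound 3 to compound 4 (0.03 log units; within the scatter), which would stay within the scatter. The estimated value for compound 4 in this assay is 10000 nM, with a range from 4000 nM to 25000 nM.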

Compound 4, concentration for 50% growth inhibition: 490 nM
The estimate for compound 4 lay 20-fold (1.31 log units) above the measured number, outside the stated range (below it).
By their numbers in this assay, from the lowest: compound 4; then compounds 1, 3 and 2 (each within the scatter of the next, the first and the last beyond it).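

On this aromatic carbon, meta to a large group, the swap of hydroxy for methyl had stayed within the scatter in this assay, with a 1.8-fold lower number from compound 2 to compound 3 (0.26 log units; within the scatter), so the position could have seemed indifferent to its substituent. Nitro ends that reading, with a 19-fold lower number from compound 3 to compound 4 (1.28 log units; beyond the scatter) and a 35-fold lower number from compound 2 to compound 4 (1.55 log units; beyond the scatter), which shows that the number at this position can move a long way with the identity of the group, and that methyl and hydroxy do not mark the range open to it. The change brings in nitrogen and oxygen where methyl held a single carbon, and it adds 2 hydrogen-bond acceptors, but nothing available accounts for why nitro stands apart from the other two groups.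

The compounds shown leave open whether this drop belongs to nitro alone or would also appear with a nitrile, a trifluoromethyl group, a carboxylic acid or an amine on the same carbon. They also leave open whether nitro would give a similar number from another carbon of the ring, and whether the drop would carry over to cells other than these.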